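The compounds below may be only part of what the source reports. "The series", "measured", "known", "first", "only" and "open" are said of these compounds alone.

Of the compounds shown here, three sharing one core have been tested in a functional assay on HEK293 cells for agonist activity at G-protein coupled receptor 39 (Homo sapiens), read by scintillation proximity assay and inositol phosphate accumulation, with a stated time of 75 min, in the presence of a further agent that is not named here; a higher number here means that more compound is needed for the effect, a lower number that less compound is needed. Compound 1 `Cc1nn(-c2ncnc3nc[nH]c23)c2c1C(C(=O)Nc1ccccc1)CC(=O)N2` gives 10 nM. Compound 2 `CCCCCCCCOC1CC(=O)Nc2c1c(C)nn2-c1ncnc2nc[nH]c12` gives 8 nM, and compound 3 `Cc1nn(-c2ncnc3nc[nH]c23)c2c1C(c1ccc(OC(C)C)cc1)CC(=O)N2` gives 18 nM. Compound 1 thus sits between the other two, with the step of a 1.3-fold lower number from compound 1 to compound 2 (0.10 log units; within the scatter) and the step of a 1.8-fold higher number from compound 1 to compound 3 (0.26 log units; within the scatter) both small. Compound 4 `Cc1noc(C)c1COC1CC(=O)Nc2c1c(C)nn2-c1ncnc2nc[nH]c12` carries the change ((3,5-dimethyl-1,2-oxazol-4-yl)methoxy in place of phenylcarbamoyl on a saturated ring carbon). The closest guide is the step from compound 1 to compound 2, where another ether chain took the same place and the number barely moved; the step from compound 2 to compound 3 was a 2.3-fold higher number from compound 2 to compound 3 (0.35 log units; beyond the scatter). A step of about a 1.1-fold higher number from compound 1 to compound 4 (0.04 log units; within the scatter) is therefore expected, not beyond the scatter. For compound 4 the expected value in this assay is 11 nM, within a range of 4 nM to 30 nM.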

Compound 4, half-maximal effective concentration: 5 nM
Estimate against measurement, compound 4: 2.2-fold (0.34 log units) above, within the range that was stated.
By their numbers in this assay, from the lowest: compounds 4, 2, 1 and 3 (each within the scatter of the next, the first and the last beyond it).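

In this assay this ring carbon accepts an ether ending in a five-membered aromatic ring with 2 hetero atoms as well as it accepts the octyloxy chain or phenylcarbamoyl: both a 1.6-fold lower number from compound 2 to compound 4 (0.20 log units; within the scatter) and a 2.0-fold lower number from compound 1 to compound 4 (0.30 log units; within the scatter) lie within the scatter. Among the new steps only a 3.6-fold lower number from compound 3 to compound 4 (0.56 log units; beyond the scatter) lies beyond it and again leaves 4-isopropoxyphenyl on the higher side, though compound 1 stays within the scatter of both compound 3 and compound 4. Nothing measured here gives a reason for these steps.
Going by these compounds, whether a primary amine or a carboxylic acid on this ring carbon would keep numbers of this size remains open, as does the effect of a shorter ether such as methoxy.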